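The source may report more compounds than this note shows. Statements on the series, on what has been measured and on what is new or still open speak of the compounds shown alone.

Of the compounds shown here, three sharing one core have been measured in a functional assay on HL-60 cells (Homo sapiens) for antiproliferative activity, with a stated time of 24 h; a higher number here means a weaker inhibitor, a lower number a stronger inhibitor. Compound 1 `NC(=O)c1c(NC(=O)c2ccccc2Cl)sc2c1CCN(C(=S)Nc1ccccc1C(F)(F)F)C2` gives 10600 nM, compound 2 `Cc1ccccc1NC(=S)N1CCc2c(sc(NC(=O)c3ccccc3Cl)c2C(N)=O)C1` gives 22600 nM, and compound 3 `COc1ccccc1NC(=S)N1CCc2c(sc(NC(=O)c3ccccc3Cl)c2C(N)=O)C1` gives 40900 nM. Among these, compound 3 carries the highest number: the step of a 3.9-fold higher number from compound 1 to compound 3 (0.59 log units; beyond the scatter) lies beyond the scatter, whereas the step of a 1.8-fold higher number from compound 2 to compound 3 (0.26 log units; within the scatter) does not, so compound 3 and compound 2 cannot be separated. The step of a 2.1-fold higher number from compound 1 to compound 2 (0.33 log units; beyond the scatter) is modest but beyond the scatter.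

The next compound, compound 4 `NC(=O)c1c(NC(=O)c2ccccc2Cl)sc2c1CCN(C(=S)Nc1cccnc1)C2`, differs from compound 3 in that (pyridin-3-yl in place of 2-methoxyphenyl on an amide-type nitrogen). For the measured compounds named here, each of the three measured steps swaps one substituent for another on an aromatic carbon of a phenyl; none exchanges the ring itself, and none removes the substituent, so no measured step bears directly on this change. Because the measured steps of a 3.9-fold higher number from compound 1 to compound 3 (0.59 log units; beyond the scatter) and a 2.1-fold higher number from compound 1 to compound 2 (0.33 log units; beyond the scatter) have been modest and the rest of compound 4 is unchanged, the step from compound 3 to compound 4 in this assay is expected to be a 1.4-fold lower number from compound 3 to compound 4 (0.13 log units; within the scatter). For compound 4 the estimated value in this assay is 30000 nM, with an expected range from 8000 nM to 110000 nM.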

Compound 4, half-maximal inhibitory concentration: 33900 nM
Compound 4: the middle estimate sits 1.1-fold (0.05 log units) below what was measured, within the range that was stated.
By their numbers in this assay, from the lowest: compound 1; then compounds 2, 4 and 3 (each within the scatter of the next).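

In this assay, for the compounds shown here, putting pyridin-3-yl in place of a substituted phenyl on the amide-type nitrogen gives no readable change against two of the earlier compounds: a 1.2-fold lower number from compound 3 to compound 4 (0.08 log units; within the scatter) and a 1.5-fold higher number from compound 2 to compound 4 (0.18 log units; within the scatter) both stay within the scatter. The only separation is from the compound carrying 2-(trifluoromethyl)phenyl, a 3.2-fold higher number from compound 1 to compound 4 (0.50 log units; beyond the scatter), a modest step that leaves compound 1 as the strongest inhibitor of the four. The earlier compounds shown here varied only the substituent on a phenyl, whereas this result shows that the ring itself can be exchanged, with a hetero atom entering it, and the number still falls among those of the methyl- and methoxy-bearing compounds.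

No supporting evidence is available to explain any of these differences. The compounds shown leave open how a plain phenyl, a pyridin-2-yl, a pyridin-4-yl or a saturated ring such as cyclohexyl would read on this nitrogen, and whether the step seen with 2-(trifluoromethyl)phenyl would carry over to a 2-chlorophenyl or a 3-(trifluoromethyl)phenyl.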